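Terphenyl benzimidazoles: swapping the dimethylamino terminus

The compounds below may be only part of what the source reports. "The series", "measured", "known", "first", "only" and "open" are said of these compounds alone.

Compound 1 `Cc1ccc2[nH]c(-c3ccc(-c4ccc(-c5ccc(N(C)C)cc5)cc4)cc3)nc2c1` gives 3130 nM in a functional assay on MCF7 cells (Homo sapiens) for inhibition, read by sulforhodamine B assay (a lower number here means a stronger inhibitor of growth, a higher number a weaker inhibitor of growth), the lower of the two numbers measured. Going by the values given here, compound 2 `CN(C)c1ccc(-c2ccc(-c3ccc(-c4nc5ccccc5[nH]4)cc3)cc2)cc1` gives 41200 nM; the step of a 13-fold higher number from compound 1 to compound 2 (1.12 log units; beyond the scatter) is the only measured step, and it sits on the core, not at the terminus. Compound 3 `Cc1ccc2[nH]c(-c3ccc(-c4ccc(-c5ccc(C(F)(F)F)cc5)cc4)cc3)nc2c1` differs from compound 1 by trifluoromethyl in place of dimethylamino on an aromatic carbon. Among the compounds with values here, no measured step touches this position, so the expectation rests on compound 1 alone. The step of a 1.3-fold higher number from compound 1 to compound 3 (0.11 log units; within the scatter) is expected to stay roughly within the scatter, with a wide range. Compound 3 is therefore estimated at 4000 nM, between 1000 nM and 16000 nM.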

Compound 3, concentration for 50% growth inhibition: 31000 nM
Compound 3: middle estimate off by 7.8-fold (0.89 log units), on the low side, and the stated range ends below it.
By their numbers in this assay, from the lowest: compound 1; then compounds 3 and 2 (each within the scatter of the next).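

The dimethylamino terminus is not a silent position in this assay: trifluoromethyl in its place gives a 9.9-fold higher number from compound 1 to compound 3 (1.00 log units; beyond the scatter), a change beyond the scatter at a site the earlier pair left untouched. The step shows only that this one replacement weakens growth inhibition, not which feature of dimethylamino matters. Nothing measured here accounts for the step. As far as these compounds go, whether a primary amine, a methoxy group or a morpholine at this position would keep the level of compound 1 remains open, as does whether the same change would carry over to the core of compound 2.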